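The source may report more compounds than this note shows. Statements on the series, on what has been measured and on what is new or still open speak of the compounds shown alone.

Working notes on the series.

Compound 1 `c1ccc(-c2nnc(-c3ccc(-n4cccc4)cc3)o2)cc1` is the reference here. In an ADME assay on Vero cells (Chlorocebus sabaeus) for cytotoxicity, read by MTT assay, with a stated time of 72 h (a lower number here means a stronger inhibitor, a higher number a weaker inhibitor), compound 1 gives 250000 nM. Compound 2 `O=C(NNC(=O)c1ccc(-n2cccc2)cc1)c1ccccc1` carries a different core; how the two cores differ is not broken down here. In this assay compound 2 gives 200000 nM, and compound 3 `O=C(NNC(=O)c1ccccc1Br)c1ccc(-n2cccc2)cc1` gives 198000 nM. The change from compound 2 to compound 3 is bromo in place of hydrogen on an aromatic carbon and it produced a 1.0-fold lower number from compound 2 to compound 3 (0.00 log units; within the scatter), a step within the scatter, so nothing is said about the order of these two values. Compound 1 against compound 2 and compound 3 also falls within the scatter, so no ordering is claimed among the three measured compounds.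

Compound 4 `Brc1ccccc1-c1nnc(-c2ccc(-n3cccc3)cc2)o1` is not yet measured. It differs from compound 1 by bromo in place of hydrogen on an aromatic carbon. The place line reads the same word for word as for the change from compound 2 to compound 3, so this is the same change on the other core. Going by the values given here, the expectation for compound 4 is no change at the digits printed from compound 1 to compound 4 (within the scatter), a step of about the same size as the one seen from compound 2 to compound 3 because that change gave a 1.0-fold lower number from compound 2 to compound 3 (0.00 log units; within the scatter). Compound 4 is therefore estimated at 250000 nM, with the likely range 140000 nM to 420000 nM.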

Compound 4, half-maximal inhibitory concentration: 258000 nM
Compound 4: middle estimate off by 1.0-fold (0.01 log units), on the low side; the measured number falls inside the stated range.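

In this assay, bromo in place of hydrogen on an aromatic carbon gives a 1.0-fold higher number from compound 1 to compound 4 (0.01 log units; within the scatter). Set beside the same change on the other core, the two steps do not differ: the same change on two cores in this assay, a 1.0-fold lower number (0.00 log units; within the scatter) from compound 2 to compound 3 and a 1.0-fold higher number (0.01 log units; within the scatter) from compound 1 to compound 4, 1.0-fold (0.02 log units) apart, within the scatter of two such steps This shows only that the change, phenyl to 2-bromophenyl, gives no step beyond the scatter on either core in this assay; it does not show that a step of real size would carry from one core to the other, since neither step has any size to compare, and it rests on a single group at a single place on two cores.

Open, from the compounds shown here alone, is whether an amine or a carboxylic acid at that same place would give a step beyond the scatter in this assay. Also open, going by these compounds, is whether a longer chain there would read alike on the two cores, so that a transfer between them could be tested on a step larger than the scatter.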